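The source may report more compounds than this note shows. Statements on the series, on what has been measured and on what is new or still open speak of the compounds shown alone.

Of the compounds shown here, two have been measured so far in an assay on mitochondria (strain BALB/c) for inhibition of glycerol-3-phosphate acyltransferase 1, mitochondrial (Mus musculus), read by scintillation counting, with a stated time of 10 min; a lower number here means a stronger inhibitor, a higher number a weaker inhibitor. Compound 1 `CCCCCCCCS(=O)(=O)Nc1cc(-c2ccc(Cl)cc2)ccc1C(=O)O` gives 18100 nM in this assay. Compound 2 `CCCCCCCCS(=O)(=O)Nc1ccc(-c2cccc(Cl)c2)cc1C(=O)O` gives 8900 nM, the lower of the two numbers, and compound 1 stands higher by a margin beyond the scatter. Compound 3 `CCCCCCCCS(=O)(=O)Nc1ccc(-c2ccccc2OC)cc1C(=O)O` has not been measured. It differs from compound 2 in one place: 2-methoxyphenyl in place of 3-chlorophenyl on an aromatic carbon. Within the data shown here, no measured pair shows this change, so its effect is open; a modest rise in the number is expected, near the edge of the scatter. The expected step is a 1.7-fold higher number from compound 2 to compound 3 (0.23 log units; within the scatter). Compound 3 is therefore estimated at 15000 nM, with a range from 5000 nM to 45000 nM.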

Compound 3, half-maximal inhibitory concentration: 27600 nM
Beside the measured number, compound 3's estimate is 1.8-fold (0.26 log units) below it; the measured number falls inside the stated range.
By their numbers in this assay, from the lowest: compound 2; then compounds 1 and 3 (each within the scatter of the next).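

In this assay, 2-methoxyphenyl in place of 3-chlorophenyl on this aromatic carbon brings a 3.1-fold higher number from compound 2 to compound 3 (0.49 log units; beyond the scatter), so the number at this position responds to the group it carries. The change swaps the chlorine for a methoxy group and alters where the substituent stands on the ring, and this single step cannot separate those two differences. Nothing available explains the rise in the number.

As far as these compounds go, what 3-methoxyphenyl or 2-chlorophenyl would give on this carbon remains open. So does the effect of an amine or a carboxylic acid on that ring.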